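Hydroxy in place of 1H-benzimidazol-6-yl on the amide-type nitrogen

The compounds below may be only part of what the source reports. "The series", "measured", "known", "first", "only" and "open" are said of these compounds alone.

In a functional assay on CLL cells (Homo sapiens) for cytotoxicity, read by MTT assay, with a stated time of 48 h (on this read-out lower numbers stand for an effect already at smaller amounts and higher numbers for an effect only at larger amounts of compound), compound 1 (`C=C(CC)C(=O)c1ccc(OCC(=O)Nc2ccc(C(=O)O)cn2)c(Cl)c1Cl`) gives 14900 nM, compound 2 (`C=C(CC)C(=O)c1ccc(OCC(=O)NC(CS)C(=O)OCC)c(Cl)c1Cl`) gives 4800 nM and compound 3 (`C=C(CC)C(=O)c1ccc(OCC(=O)Nc2ccc3nc[nH]c3c2)c(Cl)c1Cl`) gives 3200 nM. Compound 3 stands at the low end of these numbers, level with compound 2: a 1.5-fold lower number from compound 2 to compound 3 (0.18 log units; within the scatter). Compound 4 (`C=C(CC)C(=O)c1ccc(OCC(=O)NO)c(Cl)c1Cl`) carries hydroxy on that nitrogen: hydroxy in place of 1H-benzimidazol-6-yl on an amide-type nitrogen. The bearing steps are all changes on this nitrogen, the modest 3.1-fold lower number from compound 1 to compound 2 (0.49 log units; beyond the scatter) and a 4.7-fold lower number from compound 1 to compound 3 (0.67 log units; beyond the scatter). None of them involves hydroxy, so they give only a rough size. A modest step to a higher number is expected, a 2.2-fold higher number from compound 3 to compound 4 (0.34 log units; beyond the scatter). For compound 4 the estimate is 7000 nM, with an expected range of 2500 nM to 20000 nM.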

Compound 4, half-maximal effective concentration: 4500 nM
The estimate for compound 4 lay 1.6-fold (0.19 log units) above the measured number, and the stated range covers the measured number.
By their numbers in this assay, from the lowest: compounds 3, 4 and 2 (each within the scatter of the next); then compound 1.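

In this assay, hydroxy on the amide-type nitrogen, a group with no ring, stays level with 1H-benzimidazol-6-yl (a 1.4-fold higher number from compound 3 to compound 4 (0.15 log units; within the scatter)) and with 1-(ethoxycarbonyl)-2-sulfanylethyl (a 1.1-fold lower number from compound 2 to compound 4 (0.03 log units; within the scatter)). The substituent at this position can therefore shrink to hydroxy with the number staying at the level of compound 2 and compound 3. Only 5-carboxypyridin-2-yl stands apart (a 3.3-fold lower number from compound 1 to compound 4 (0.52 log units; beyond the scatter)).

From the compounds shown here alone, whether methoxy or an amino group on this nitrogen holds the same level, and whether the carboxylic acid of compound 1 accounts for its separation, remains open. No measurement at hand bears on this result.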